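The source may hold more compounds than are shown below. What is called first, only, known or untested is meant among the compounds shown, and "the series" means these compounds.

Compound 2, with the structure `C#CCOCCn1c(N2CCN(C)CC2)nc2ccccc21`, is one of three compounds for which results are available in a functional assay on ileum for inhibition of histamine H1 receptor (Cavia porcellus); a higher number here means a weaker inhibitor, a lower number a stronger inhibitor. In this assay compound 2 gives 12 nM. Compound 1, built on the same core as `CCOCCn1c(N2CCCN(Cc3ccccc3)CC2)nc2ccccc21` but carrying a benzyl-substituted diazepane in place of the methylpiperazine and an ethoxyethyl chain in place of the propargyloxyethyl chain, gives 15 nM in this assay, a number that sits within the usual scatter of that of compound 2, so the two cannot be placed in order. Compound 3, with the structure `CCOCCn1c(N2CCN(c3ccccc3)CC2)nc2ccccc21`, differs in carrying a phenyl group on the piperazine nitrogen. For compound 3 this assay reports only a limit, > 10000 nM, described as the limit of > 10000 nM in this assay, at which 1 of the 3 values shown sits.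

The account now turns from compound 2 to compound 4, whose structure is `COCCn1c(N2CCN(C)CC2)nc2ccccc21`. The change between them is a small one: hydrogen in place of ethynyl on a saturated chain carbon bound to an oxygen on a saturated carbon. Within the data shown here, no measured pair among the three compounds repeats this change, so its size has to be guessed. Compound 1 gives 15 nM with an ethoxyethyl chain at the same position, which suggests the ether alkyl tolerates variation. Compound 4 is therefore expected to give 20 nM, between 7 nM and 60 nM, a step of a 1.7-fold higher number from compound 2 to compound 4 (0.22 log units; within the scatter) that is expected to stay close to the scatter.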

Compound 4, half-maximal inhibitory concentration: 13 nM
The estimate for compound 4 lay 1.5-fold (0.19 log units) above the measured number, within the range that was stated.
By their numbers in this assay, from the lowest: compounds 2, 4 and 1 (each within the scatter of the next). At a limit, above all of these: compound 3.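

Among these compounds, the step of a 1.1-fold higher number from compound 2 to compound 4 (0.03 log units; within the scatter) in this assay is the first measured change that touches only this position, since compound 1 differs from compound 2 in more than one place. It shows that, with the methylpiperazine held constant, propargyloxy and methoxy on the chain give numbers that cannot be placed in order. Removing the ethynyl group, with its triple bond and both of its carbons, therefore leaves no change in this assay that can be told from the scatter, and nothing measured here speaks to why that is so.

This single pair leaves open whether the position would accept a longer chain, an amine or a carboxylic acid at the end of the ether chain as readily. Compound 3 stands at a limit, > 10000 nM, and it differs from every other compound shown in more than one place, so no step to it can be read and the part played by its phenyl group on the piperazine nitrogen remains unsettled.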